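The compounds below may be only part of what the source reports. "The series", "measured", "known", "first", "only" and "open" are said of these compounds alone.

Measured so far in a functional assay on COLO 205 cells (Homo sapiens) for cytotoxicity, read by MTT assay, with a stated time of 24 h; a lower number here means a stronger inhibitor, a higher number a weaker inhibitor:

compound 1 `COc1ccc(/C=C\C(=O)O)c(OCc2cn(-c3ccc(NC(C)=O)cc3)nn2)c1CC=C(C)C`: 22600 nM
compound 2 `COc1ccccc1-n1cc(COc2c(/C=C\C(=O)O)ccc(OC)c2CC=C(C)C)nn1`: 12200 nM
compound 3 `COc1ccc(/C=C\C(=O)O)c(OCc2cn(-c3ccccc3F)nn2)c1CC=C(C)C`: 14500 nM

Compound 3 sits second highest of the three numbers. Its nearest neighbour is compound 2, with a 1.2-fold higher number from compound 2 to compound 3 (0.08 log units; within the scatter); its furthest is compound 1, with a 1.6-fold lower number from compound 1 to compound 3 (0.19 log units; within the scatter). Both of those gaps stay inside the scatter, so nothing here separates the three compounds with any confidence.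

Compound 4 `COc1ccc(/C=C\C(=O)O)c(OCc2cn(-c3ccccc3C#N)nn2)c1CC=C(C)C` is the next step from compound 3. The change: cyano in place of fluoro on an aromatic carbon.

Among the measured compounds shown here, three measured steps bear on it, all of them exchanges of the group on the aromatic nitrogen or of a substituent on that phenyl ring: a 1.9-fold lower number from compound 1 to compound 2 (0.27 log units; within the scatter), a 1.6-fold lower number from compound 1 to compound 3 (0.19 log units; within the scatter) and a 1.2-fold higher number from compound 2 to compound 3 (0.08 log units; within the scatter). Every one of them stays within the scatter, and the step to compound 4 is of the same kind, a single substituent exchanged on that aromatic carbon. No step beyond the scatter is therefore expected in this assay, in either direction.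

The estimate for compound 4 is 13500 nM, with a range of 6500 nM to 28000 nM. This expected result amounts to a 1.1-fold lower number from compound 3 to compound 4 (0.03 log units; within the scatter).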

Compound 4, half-maximal inhibitory concentration: 3200 nM
Compound 4: middle estimate off by 4.2-fold (0.63 log units), on the high side, outside the stated range (below it).
By their numbers in this assay, from the lowest: compound 4; then compounds 2, 3 and 1 (each within the scatter of the next).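

In this assay, among the compounds shown here, the aromatic carbon ortho to a large group turns out to respond to substitution: cyano in place of fluoro gives a step beyond the scatter (a 4.5-fold lower number from compound 3 to compound 4 (0.66 log units; beyond the scatter)), which no exchange among the earlier compounds did. Cyano in place of methoxy on the same carbon also goes beyond the scatter (a 3.8-fold lower number from compound 2 to compound 4 (0.58 log units; beyond the scatter)), as does 2-cyanophenyl in place of 4-acetamidophenyl on the aromatic nitrogen (a 7.1-fold lower number from compound 1 to compound 4 (0.85 log units; beyond the scatter)), so compound 4 stands apart from all three earlier compounds, while fluoro and methoxy at this carbon remain indistinguishable. Nothing available here accounts for the difference.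

From the compounds shown here alone, whether this response belongs to the nitrile alone remains open, since a primary amide, a carboxylic acid or trifluoromethyl at the same carbon would test that. Also open, going by these compounds, is whether a nitrile elsewhere on that phenyl ring gives the same step.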